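The source may report more compounds than this note shows. Statements on the series, on what has been measured and on what is new or still open speak of the compounds shown alone.

Among the compounds with values here, in a functional assay on cells (Neutrophil, Homo sapiens) for inhibition, with a stated time of 10 min (a lower number here means a stronger inhibitor, a higher number a weaker inhibitor), compound 1 `CCOC(=O)c1cnn(CC(C)O)c1NC(=O)NCc1ccccc1` gives 0.00054 nM, the lowest of the two numbers measured so far. Within the data shown here, the only comparison available is compound 2 `CCOC(=O)c1cnn(C)c1NC(=O)NCc1ccccc1`, which gives 1.3 nM. That comparison is large: a 2400-fold higher number from compound 1 to compound 2 (3.38 log units; beyond the scatter), with hydrogen in place of 1-hydroxyethyl on a saturated chain carbon bound to an aromatic nitrogen.

Compound 3 `CCOC(=O)c1cnn(CC(C)O)c1NC(=O)Nc1ccccc1F` keeps that 1-hydroxyethyl-bearing chain and changes the other end of the molecule, with 2-fluorophenyl in place of benzyl on an amide-type nitrogen. Among the measured compounds shown here, the one measured step therefore does not test this swap directly. For the measured compounds named here, it shows only that a single change in this small set can move the number a great deal. Going by the values given here, with compound 1 at 0.00054 nM, a new change seems more likely to raise the number than to lower it, though no measured pair reports on the direction. Among the compounds with values here, a sizeable rise is expected, smaller than the one step seen so far, and the estimated change is a 37-fold higher number from compound 1 to compound 3 (1.57 log units; beyond the scatter). For compound 3 the estimated value is 0.02 nM, with an expected range from 0.0005 nM to 1 nM.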

Compound 3, half-maximal inhibitory concentration: 0.00055 nM
Compound 3: the middle estimate sits 36-fold (1.56 log units) above what was measured; the range from low to high includes it.
By their numbers in this assay, from the lowest: compounds 1 and 3 (each within the scatter of the next); then compound 2.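

In this assay the swap at the amide-type nitrogen gives a 1.0-fold higher number from compound 1 to compound 3 (0.01 log units; within the scatter), so the numbers for these two compounds cannot be told apart. Within the data shown here, the earlier step concerned only the chain on the aromatic nitrogen at the other end of the molecule, whereas this is the first reading at the amide-type nitrogen, and it shows that benzyl and 2-fluorophenyl, both with 7 heavy atoms and one six-membered aromatic ring, are interchangeable here in this assay, at least with the 1-hydroxyethyl-bearing chain in place. Nothing available explains why these two groups read alike.

This single pair cannot separate the contribution of the fluorine from that of removing the saturated carbon that links the ring to the nitrogen, a question that plain phenyl would address, while a longer chain such as 2-phenylethyl would show how far the ring can sit from that nitrogen without moving the number. From the compounds shown here alone, it also remains open whether the same swap would read alike in the setting of compound 2, where the large step shows that the number starts from a very different level.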